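This account rests on a few compounds, and the source may have more. Where it says the series, first, only, none or still open, it means among the compounds named here.

Compound 1 `C#CCNC1CCc2c(OCCCCN3CCN(c4cccc5c4ccn5Cc4cccc(Cl)c4)CC3)cccc21` and compound 2 `C#CCNC1CCc2c(OCCCCN3CCN(c4cccc5c4ccn5S(=O)(=O)c4ccccc4)CC3)cccc21` share a core and differ in one place: phenylsulfonyl in place of 3-chlorobenzyl on an aromatic nitrogen. In an assay on BTI cells for inhibition of Amine oxidase [flavin-containing] B (Homo sapiens), read by fluorescence, with stated times of 30 min and 1 h, tested at 1 uM (a higher number here means more inhibition at the concentration tested (going by the name of the read-out), a lower number less inhibition), compound 1 gives 100%, while compound 2 gives 44%; the step of a number 56 percentage points lower from compound 1 to compound 2 (beyond the scatter) lies well beyond the scatter of this assay. Compound 3 `C#CCN(C)Cc1ccc(OCCCCN2CCN(c3cccc4c3ccn4Cc3cccc(Cl)c3)CC2)cc1` carries the same 3-chlorobenzyl group on a different core; how its core differs from that of compound 1 is not broken down here. In this assay compound 3 gives 85%. Compound 4 `C#CCN(C)Cc1ccc(OCCCCN2CCN(c3cccc4c3ccn4S(=O)(=O)c3ccccc3)CC2)cc1` is not yet measured and differs from compound 3 by phenylsulfonyl in place of 3-chlorobenzyl on an aromatic nitrogen, the same kind of change seen in the measured pair. Because the change from compound 1 to compound 2 gave a number 56 percentage points lower from compound 1 to compound 2 (beyond the scatter), a step of comparable size is expected, a number 50 percentage points lower from compound 3 to compound 4 (beyond the scatter). Compound 4 is therefore estimated at 35%, likely between 15% and 60%.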

Compound 4, a percentage reported as inhibition, at one concentration (the size of the read-out at that concentration, not a potency): 51%
The estimate for compound 4 lay 16 percentage points below the measured number; the range from low to high includes it.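

Phenylsulfonyl in place of 3-chlorobenzyl on the aromatic nitrogen again gives a number 34 percentage points lower from compound 3 to compound 4 (beyond the scatter) in this assay and so lowers the number on both cores shown. The direction of the change carries over from one core to the other, but its size does not: the same change on two cores in this assay, a number 56 percentage points lower (beyond the scatter) from compound 1 to compound 2 and a number 34 percentage points lower (beyond the scatter) from compound 3 to compound 4, 22 percentage points apart, beyond the scatter of two such steps. These two pairs do not show why the size differs, and as readings at a single concentration they say nothing about potency on either core.

The compounds shown leave open how an unsubstituted benzyl, an acetyl or a methyl on that nitrogen would compare on either core. They also leave open whether a shorter chain would change the size of the step.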